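Swapping a Chloro-Aryl for a Benzyl on the Ether Arm

This account rests on a few compounds, and the source may have more. Where it says the series, first, only, none or still open, it means among the compounds named here.

Of the compounds shown here, two sharing one core have been tested, compound 1 `CC1(C)C(=O)Nc2ccc(OCc3ccc(F)cc3)cc21` and compound 2 `CC1(C)C(=O)Nc2ccc(OCc3cccc(Cl)c3)cc21`, and a third, compound 3 `CC1(C)C(=O)Nc2ccc(OCCc3ccccc3)cc21`, has not. In an assay on cells for inhibition of Amine oxidase [flavin-containing] B (Homo sapiens), read by fluorescence, with stated times of 30 min and 15 min, tested at 1 uM (a higher number here means more inhibition at the concentration tested (going by the name of the read-out), a lower number less inhibition), compound 1 is reported as "not active" (no number reported), without a number. In this assay, among the compounds with values here, compound 2 gives 21.1%, which makes compound 2 the holder of the only number in the set; compound 1 stands beside it with no figure of its own, so nothing can be said about their order.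

Compound 3 differs from compound 2 in one place: benzyl in place of 3-chlorophenyl on a saturated chain carbon bound to an oxygen on an aromatic ring. The chlorine leaves and an extra chain carbon is inserted between the aromatic ring and the ether oxygen. Within the data shown here, no measured pair shows the effect of such a change, so the expected step in this assay is drawn only from the weak value of compound 2 and the inactivity of compound 1: compound 3 is expected to sit at or a little below compound 2, a step of a number 9.1 percentage points lower from compound 2 to compound 3 (within the scatter) that may not exceed the scatter. The estimate for compound 3 is 12%, with a range from 0% to 30%.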

Compound 3, a percentage reported as inhibition, at one concentration (the size of the read-out at that concentration, not a potency): "not active" (no number reported)
For compound 3 the study gives words and no number; no gap can be computed for the estimate.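

Within the data shown here, compound 3 is reported in words only, so no step from compound 2 to compound 3 can be read in this assay. The compounds shown leave open whether losing the chlorine or gaining the extra chain carbon matters more, since compound 3 differs from compound 2 in both at once. No measurement shown here bears on this result.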